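Trading a Benzyl-Type Arm for tert-Butyl

A few compounds are considered here, and "the series" means these few. Any claim that something is new, unique, unknown or untested is made for them only; others in the source may bear on it.

Measured compounds in an in vitro functional assay on cells for agonist activity at Bombesin receptor subtype-3 (Homo sapiens), read by luminescence and calcium flux; a lower number here means that less compound is needed, a higher number that more compound is needed for the effect:
- compound 1, `Cc1ccccc1Cc1cnc(CCc2ccc(-c3ccccc3C(=O)O)cc2)[nH]1`: compound 1 gives 127 nM
- compound 2, `O=C(O)c1ccccc1-c1ccc(CCc2ncc(CC3CCCC3)[nH]2)cc1`: compound 2 gives 133 nM
- compound 3, `N#Cc1cccc(Cc2cnc(CCc3ccc(-c4ccccc4C(=O)O)cc3)[nH]2)c1`: compound 3 gives 812 nM

The three measured compounds share one core and differ only in the group carried on one aromatic carbon of that core. Compound 3 stands highest of the three numbers; its nearest neighbour is compound 2, and compound 1 lies only slightly further away. The two compounds below it sit together: a 1.0-fold higher number from compound 1 to compound 2 (0.02 log units; within the scatter). Both steps into compound 3 are modest but clear: a 6.4-fold higher number from compound 1 to compound 3 (0.81 log units; beyond the scatter), and a 6.1-fold higher number from compound 2 to compound 3 (0.79 log units; beyond the scatter).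

Compound 4, `CC(C)(C)c1cnc(CCc2ccc(-c3ccccc3C(=O)O)cc2)[nH]1`, makes a further change at the same position: tert-butyl in place of 3-cyanobenzyl on an aromatic carbon. This removes the whole 3-cyanobenzyl group that separates compound 3 from the other two, and puts in something small and saturated. The comparison of compound 1 with compound 2 shows that a saturated group in place of an aromatic one leaves the number unchanged within the scatter, so the loss of the ring itself need not cost anything. The step from compound 3 is therefore expected to run downward, roughly undoing the rise seen in the steps into compound 3, although the much smaller size of tert-butyl leaves the exact size open. Compound 4 is expected to give 250 nM, within a range of 80 nM to 800 nM, meaning a 3.2-fold lower number from compound 3 to compound 4 (0.51 log units; beyond the scatter).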

Compound 4, half-maximal effective concentration: 4330 nM
For compound 4 the middle estimate is 17-fold (1.24 log units) below the measured one, and the stated range ends below it.
By their numbers in this assay, from the lowest: compounds 1 and 2 (each within the scatter of the next); then compound 3; then compound 4.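

In this assay, among the compounds shown here, this position proves less tolerant than the earlier compounds suggested: each of them carries a ring on a saturated chain carbon, whereas tert-butyl has no ring, and the number rises in every comparison, with a 5.3-fold higher number from compound 3 to compound 4 (0.73 log units; beyond the scatter), a 33-fold higher number from compound 2 to compound 4 (1.51 log units; beyond the scatter) and a 34-fold higher number from compound 1 to compound 4 (1.53 log units; beyond the scatter). The two large steps show that a saturated group is not enough by itself, since cyclopentylmethyl in compound 2 and tert-butyl in compound 4 are both saturated yet lie far apart, and the modest step shows that compound 3 did not mark the upper end of the series. Nothing available here bears on why the number rises at this position.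

The compounds shown leave open whether the rise comes from losing the ring, losing the saturated chain carbon that carries it, or the smaller size of the group, as all three change together in compound 4. Neopentyl, which keeps the tert-butyl group but places it on a chain carbon, and cyclopentyl set directly on the aromatic carbon would help separate these possibilities.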